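A Methyl on the Benzamide Ring of Compound 3

This account rests on a few compounds, and the source may have more. Where it says the series, first, only, none or still open, it means among the compounds named here.

Compound 1, `CC(=O)Nc1cccc(NC(=O)COc2ccc3c(=O)ccoc3c2)c1`, gives 2500 nM in an assay on isolated protein for inhibition of Rho-associated protein kinase 1 (Homo sapiens), read by scintillation counting, radiometric assay and 33P incorporation, with a stated time of 40 min, in the presence of a further agent that is not named here; a lower number here means a stronger inhibitor, a higher number a weaker inhibitor.
Compound 2, `CCCC(=O)Nc1cccc(NC(=O)COc2ccc3c(=O)ccoc3c2)c1`, gives 1430 nM.
Compound 3, `O=C(COc1ccc2c(=O)ccoc2c1)Nc1cccc(NC(=O)c2ccccc2)c1`, gives 120 nM.

All three share one core and differ only in the group on the second amide carbonyl. Compound 3 stands lowest of the three numbers, so it is the strongest inhibitor here: the step of a 21-fold lower number from compound 1 to compound 3 (1.32 log units; beyond the scatter) and the step of a 12-fold lower number from compound 2 to compound 3 (1.08 log units; beyond the scatter) are both large and beyond the scatter, while the step of a 1.7-fold lower number from compound 1 to compound 2 (0.24 log units; within the scatter) stays within it.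

Compound 4, `Cc1ccc(C(=O)Nc2cccc(NC(=O)COc3ccc4c(=O)ccoc4c3)c2)cc1`, carries one further change: methyl in place of hydrogen on an aromatic carbon, para to a large group, turning benzamido into ((4-methylphenyl)carbonyl)amino.

For the measured compounds named here, no measured step adds a group to that aromatic ring; the measured steps swap the whole group on the carbonyl. The only small addition of saturated carbon, the step of a 1.7-fold lower number from compound 1 to compound 2 (0.24 log units; within the scatter), stayed within the scatter. On that basis a small step is expected, with no clear direction, and compound 4 is estimated at 100 nM, between 35 nM and 300 nM. The expected step of a 1.2-fold lower number from compound 3 to compound 4 (0.08 log units; within the scatter) therefore lies within the scatter.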

Compound 4, half-maximal inhibitory concentration: 183 nM
For compound 4 the middle estimate is 1.8-fold (0.26 log units) below the measured one; low and high end bracket the measured number.
By their numbers in this assay, from the lowest: compounds 3 and 4 (each within the scatter of the next); then compounds 2 and 1 (each within the scatter of the next).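

For the compounds shown here, compound 4 is the first case here where a group is added to the aromatic ring on the carbonyl, rather than the whole group being swapped, and the added methyl, on an aromatic carbon para to a large group, gives a 1.5-fold higher number from compound 3 to compound 4 (0.18 log units; within the scatter). The advantage of an aromatic ring on that carbonyl also holds with the methyl in place: 4-methylphenyl in place of propyl gives a 7.8-fold lower number from compound 2 to compound 4 (0.89 log units; beyond the scatter) and is a modest step, while 4-methylphenyl in place of methyl gives a 14-fold lower number from compound 1 to compound 4 (1.14 log units; beyond the scatter) and is a large one, so compounds 3 and 4 both stay clearly apart from compounds 1 and 2. No other measurement on these compounds offers an explanation for any of these numbers.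

From the compounds shown here alone, a single methyl at a single place says little about how this ring responds to other groups, so it remains open whether a methoxy, a chlorine, an amine or a carboxylic acid at that same carbon would leave the number as unchanged as methyl did. Going by these compounds, it also remains open whether a longer chain there, such as butyl, would still fit this picture.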